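The source may report more compounds than this note shows. Statements on the series, on what has been measured and on what is new or still open speak of the compounds shown alone.

Measured compounds:
compound 1, `Cc1nc2c(OCc3ccccc3)cccn2c1CCC#N`, gives 40% in a functional assay on the whole organism with Rattus norvegicus as the target, with a stated time of 4 h, at a dose of 40 mg/kg by the intraperitoneal route; a higher number here means more inhibition at the dose given (going by the name of the read-out), a lower number less inhibition
compound 2, `[C-]#[N+]Cc1c(C)nc2c(OCc3ccccc3)cccn12`, gives 96%
compound 3, `Cc1nc2c(OCc3ccccc3)cccn2c1C[S+](C)[O-]`, gives 0%

Compound 3 stands lowest of the three, reached by the steps of a number 40 percentage points lower from compound 1 to compound 3 (beyond the scatter) and a number 96 percentage points lower from compound 2 to compound 3 (beyond the scatter). Compound 4, `Cc1nc2c(OCc3ccccc3)cccn2c1CC1=NCCN1`, differs from compound 3 by a group of 5 heavy atoms (3 carbon, 2 nitrogen; one five-membered non-aromatic ring with 2 hetero atoms) in place of a group of 3 heavy atoms (1 carbon, 1 oxygen, 1 sulfur; no ring), on a saturated chain carbon bound to an aromatic carbon. Both measured steps into compound 3 exchanged the group at this same place, and each was large, so an exchange here can move the read-out a long way. Within the data shown here, the group that enters in compound 4 matches none of the groups measured so far, so no step points its direction; only the lowest possible starting point of compound 3 suggests room upward. An upward step of a number 40 percentage points higher from compound 3 to compound 4 (beyond the scatter) is therefore expected for compound 4. The estimate for compound 4 is 40%, expected between 5% and 85%.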

Compound 4, a percentage reported as inhibition, in the whole organism at one dose (the size of the read-out at that dose, not a potency): 69%
Beside the measured number, compound 4's estimate is 29 percentage points below it; the range from low to high includes it.
By their numbers in this assay, from the lowest: compound 3; then compound 1; then compound 4; then compound 2.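

In this assay a ring on this saturated chain carbon is compatible with a high number: a number 69 percentage points higher from compound 3 to compound 4 (beyond the scatter) and a number 29 percentage points higher from compound 1 to compound 4 (beyond the scatter) place the five-membered non-aromatic ring ahead of both groups of 3 heavy atoms. Group size alone does not set the order, as a number 27 percentage points lower from compound 2 to compound 4 (beyond the scatter) leaves the group of 2 heavy atoms on top. The compounds shown leave open whether an open-chain amine or a six-membered ring here would keep this number. No measured evidence accounts for these differences.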